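A few compounds are considered here, and "the series" means these few. Any claim that something is new, unique, unknown or untested is made for them only; others in the source may bear on it.

Compound 1 `COc1cc(OC)c(-c2coc3cc(OCC=C(C)C)ccc3c2=O)cc1OC`: 280 nM
Compound 2 `COc1cc(OC)c(-c2coc3cc(OCc4ccccc4C)ccc3c2=O)cc1OC`: 1860 nM
Compound 3 `COc1cc(OC)c(-c2coc3cc(OCc4ccccc4C(F)(F)F)ccc3c2=O)cc1OC`: 6550 nM

These three values come from a functional assay on HepG2 cells (Homo sapiens) for antiproliferative activity, read by MTT assay, with a stated time of 24 h; on this read-out lower numbers stand for stronger inhibition and higher numbers for weaker inhibition. Compound 3 carries the highest number of the three: compound 2 lies nearest and compound 1 furthest, and both of those steps reach beyond the scatter. Compound 4 `COc1cc(OC)c(-c2coc3cc(OCc4cccc(C(F)(F)F)c4)ccc3c2=O)cc1OC` differs from compound 3 in one way: 3-(trifluoromethyl)phenyl in place of 2-(trifluoromethyl)phenyl on a saturated chain carbon bound to an oxygen on an aromatic ring. For the measured compounds named here, no measured step moves a group to another place on the same ring: a 6.6-fold higher number from compound 1 to compound 2 (0.82 log units; beyond the scatter) and a 23-fold higher number from compound 1 to compound 3 (1.37 log units; beyond the scatter) exchange the whole group on the chain carbon, and a 3.5-fold higher number from compound 2 to compound 3 (0.55 log units; beyond the scatter) exchanges one group for another on one ring carbon. The data are silent on the new position itself, so the expected step for compound 4 is small, a 1.3-fold lower number from compound 3 to compound 4 (0.12 log units; within the scatter), possibly none beyond the scatter. Compound 4 is estimated at 5000 nM, within a range from 1500 nM to 16000 nM.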

Compound 4, half-maximal inhibitory concentration: 610 nM
Compound 4: middle estimate off by 8.2-fold (0.91 log units), on the high side; measured number outside the range, below it.
By their numbers in this assay, from the lowest: compound 1; then compound 4; then compound 2; then compound 3.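

In this assay, the two groups have the same atoms joined differently, yet 3-(trifluoromethyl)phenyl in place of 2-(trifluoromethyl)phenyl gives (an 11-fold lower number from compound 3 to compound 4 (1.03 log units; beyond the scatter)), so where the trifluoromethyl sits on this ring matters as well as which group is present. The 3-(trifluoromethyl)phenyl group also improves on 2-methylphenyl (a 3.0-fold lower number from compound 2 to compound 4 (0.48 log units; beyond the scatter)), but the 2-methylprop-1-en-1-yl group keeps the lower number (a 2.2-fold higher number from compound 1 to compound 4 (0.34 log units; beyond the scatter)). Nothing available here explains this effect of position. Going by these compounds, it remains open how a nitrile or an amine in place of the trifluoromethyl would compare, and whether a longer chain on the saturated carbon would keep this activity.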